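Ester chain variation on the shared core

A few compounds are considered here, and "the series" means these few. Any claim that something is new, unique, unknown or untested is made for them only; others in the source may bear on it.

Measured so far in a functional assay on SK-BR-3 cells (Homo sapiens) for antiproliferative activity, read by MTT assay, with a stated time of 72 h; a higher number here means a weaker inhibitor, a lower number a stronger inhibitor:
compound 1 `C/C=C1/[C@H](O[C@@H]2O[C@H](COC(C)=O)[C@@H](OC(C)=O)[C@H](OC(C)=O)[C@H]2OC(C)=O)OC=C(C(=O)OC)[C@H]1CC(=O)OCCC`: 6600 nM
compound 2 `C/C=C1/[C@H](O[C@@H]2O[C@H](CO)[C@@H](O)[C@H](O)[C@H]2O)OC=C(C(=O)OC)[C@H]1CC(=O)OCc1ccccc1`: a limit
compound 3 `C/C=C1/[C@H](O[C@@H]2O[C@H](CO)[C@@H](O)[C@H](O)[C@H]2O)OC=C(C(=O)OC)[C@H]1CC(=O)OCCc1ccc2c(c1)OCCO2`: a limit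

Compound 1 is the only one of the three with a number in this assay, 6600 nM. Compound 2 gives only a limit of this assay, > 15000 nM. Compound 3 likewise gives only a limit, > 20000 nM. Between the two, a step that the two limits leave unreadable from compound 2 to compound 3, so no size can be read from that pair.

Compound 4 `C/C=C1/[C@H](O[C@@H]2O[C@H](COC(C)=O)[C@@H](OC(C)=O)[C@H](OC(C)=O)[C@H]2OC(C)=O)OC=C(C(=O)OC)[C@H]1CC(=O)OCCC(C)C` differs from compound 1 by isopropyl in place of methyl on a saturated chain carbon, two bonds along the chain from an oxygen next to a carbonyl group. Within the data shown here, no measured step bears directly on this change: the step from compound 2 to compound 3 is unreadable, and compound 2 and compound 3 also differ from compound 1 elsewhere in the molecule. With nothing in the series pointing either way, a step no larger than the usual scatter is expected, a 1.2-fold lower number from compound 1 to compound 4 (0.08 log units; within the scatter). Compound 4 is therefore estimated at 5500 nM in this assay, with a range from 2000 nM to 15000 nM.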

Compound 4, half-maximal inhibitory concentration: > 15000 nM
Compound 4 was reported as a limit; the forecaster's own chance of this, stated with the estimate: 15%; middle value at least 2.7-fold (0.43 log units) away from the limit.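

Among these compounds, replacing methyl with isopropyl on a saturated chain carbon, two bonds along the chain from an oxygen next to a carbonyl group, gives an at least 2.2-fold higher number from compound 1 to compound 4 (0.35 log units; beyond the scatter) in this assay and is the first readable step. The series therefore does not tolerate every extension at this position, since propyl to isopentyl alone moves the number beyond the scatter. The value of compound 4 is a limit and not a number, so this step has a lower bound but no full size: the limit of > 15000 nM in this assay, at which 2 of the 4 values shown sit.

As far as these compounds go, whether branching or added chain length carries the step stays open, and a straight pentyl chain would separate the two. An amine at the chain end would show whether this position accepts anything other than carbon there.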